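The source may hold more compounds than are shown below. What is called first, only, known or untested is meant among the compounds shown, and "the series" means these compounds.

Measured in a functional assay on MDA-MB-468 cells (Homo sapiens) for antiproliferative activity, read by MTT assay, with a stated time of 72 h; a lower number here means a stronger inhibitor, a higher number a weaker inhibitor:
- Compound 1 `O=C(Nc1ccc(Cl)c(-c2nnc3c(Cl)cccn23)c1)c1ccccn1`: > 100000 nM (a limit)
- Compound 2 `O=C(Nc1ccc(Cl)c(-c2nnc3c(Cl)cccn23)c1)c1cccc(Cl)c1`: 54800 nM
- Compound 3 `CS(=O)(=O)c1ccc(C(=O)Nc2ccc(Cl)c(-c3nnc4c(Cl)cccn34)c2)cc1`: > 100000 nM (a limit)

Compound 1 has no number, and its > 100000 nM is only a limit. The same holds across much of this small set: the limit of > 100000 nM in this assay, at which 2 of the 3 values shown sit.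

The next compound is compound 4 `O=C(Nc1ccc(Cl)c(-c2nnc3c(Cl)cccn23)c1)c1ccon1`, which carries 1,2-oxazol-3-yl in place of pyridin-2-yl on a carbonyl carbon.

Three measured steps change the same place. The first is an at least 1.8-fold lower number from compound 1 to compound 2 (0.26 log units; that floor lies within the scatter). The second is an at least 1.8-fold higher number from compound 2 to compound 3 (0.26 log units; that floor lies within the scatter). The third is a step that the two limits leave unreadable from compound 1 to compound 3. The first two give only floors, and both floors lie within the scatter, while the third cannot be sized. Compound 2 is the only one of the three to give a number, 54800 nM, so replacing the pyridin-2-yl group has not yet been shown to give a gain beyond the scatter.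

No clear step is therefore expected in this assay, and no direction can be firmly expected either. The estimated step is an at least 1.1-fold lower number from compound 1 to compound 4 (0.04 log units; that floor lies within the scatter). For compound 4 the estimate is 90000 nM, with an expected range of 40000 nM to 200000 nM, and a reported limit rather than a number is also expected to be likely.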

Compound 4, half-maximal inhibitory concentration: > 100000 nM
Compound 4: only a limit was reported; the forecaster's own chance of this, stated with the estimate: 65%; middle value at least 1.1-fold (0.04 log units) away from the limit.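

In this assay compound 4 gives > 100000 nM, which is a limit and not a number. Within the data shown here, the one readable step is an at least 1.8-fold higher number from compound 2 to compound 4 (0.26 log units; that floor lies within the scatter), while the steps from compound 1 and from compound 3 to compound 4 cannot be read. The result adds a five-membered aromatic ring, 1,2-oxazol-3-yl, to the six-membered pyridin-2-yl and the 4-(methylsulfonyl)phenyl among the groups on this carbonyl carbon that yield no number, and the set now rests mostly on one value: the limit of > 100000 nM in this assay, at which 3 of the 4 values shown sit.

Compound 2 remains the only compound here with a number, and no step shown for this position goes beyond the scatter, so it is still open whether any change at this carbonyl carbon moves the series measurably. As far as these compounds go, an amine or a carboxylic acid on the aromatic ring, or a longer chain in place of that ring, would test this position, and changes elsewhere on the shared core remain open as well.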